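The compounds below may be only part of what the source reports. "The series", "measured", "known", "first", "only" and "open" are said of these compounds alone.

Two stereoisomers of one constitution have been run in an ADME assay on the whole organism (Mus musculus, strain C57BL/6) for pharmacokinetics, read by HPLC, with a stated time of 6 h, at a dose of 25 mg/kg by the oral route; a lower number here means less compound in the circulation, a higher number more compound in the circulation at the dose given. Compound 1 `O=C(N[C@H](CO)C(=O)O)[C@@H]1C[C@H](O)CN1` gives 22200 nM. Among the compounds with values here, compound 2 `O=C(O)[C@H](CO)NC(=O)[C@@H]1C[C@@H](O)CN1` gives 520 nM and stands at the lower of the two numbers; its only neighbour is compound 1, reached by a 43-fold lower number from compound 1 to compound 2 (1.63 log units; beyond the scatter). That step rests on the fact that compounds 1 and 2 differ only in the configuration as drawn alone, and it moves two stereo elements at once, so the share of the ring carbon by itself is not isolated. Compound 3 `O=C(O)[C@H](CO)NC(=O)[C@@H]1C[C@H](O)CN1` differs from compound 2 in one place: the two compounds have the same atoms and bonds and differ only in configuration as drawn: 1 of 3 stereo elements differ; a stereocentre at a saturated ring carbon is drawn R in compound 2 and S in compound 3. The ring carbon of compound 3 thus carries the configuration drawn for compound 1, while the chain carbon stays as in compound 2. Within the data shown here, the one measured step that bears on this was large, but since it changed two elements together, a rise of uncertain size, smaller than that step, is expected here. For compound 3 in this assay the estimate is 3000 nM, with a range of 450 nM to 20000 nM, an expected step of a 5.8-fold higher number from compound 2 to compound 3 (0.76 log units; beyond the scatter).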

Compound 3, maximal plasma concentration: 1050 nM
The estimate for compound 3 lay 2.9-fold (0.46 log units) above the measured number; measured number inside the range.
By their numbers in this assay, from the lowest: compound 2; then compound 3; then compound 1.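

Taken singly, the two stereo elements changed together in the earlier step no longer weigh the same in this assay. The saturated ring carbon accounts for only a 2.0-fold higher number from compound 2 to compound 3 (0.31 log units; beyond the scatter), whereas the saturated chain carbon accounts for a 21-fold lower number from compound 1 to compound 3 (1.33 log units; beyond the scatter), so most of the earlier gap sits with the chain carbon. That large step comes from configuration at one carbon alone, with the constitution unchanged: the fact that compounds 1 and 3 differ only in the configuration as drawn

On these data alone, the ring carbon step is known only with the chain carbon drawn S, so its size with the chain carbon drawn R stays open, as does the role of the third stereo element, drawn alike in all three compounds. Also open, as far as these compounds go, is how a methyl ether at the ring hydroxyl or a methyl ester in place of the carboxylic acid would read on the configuration of compound 1.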